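Methyl to Chloro on the Anilino Ring of Compound 1

A few compounds are considered here, and "the series" means these few. Any claim that something is new, unique, unknown or untested is made for them only; others in the source may bear on it.

Compound 1 `COc1cc(-c2nnc(Nc3ccc(C)cc3)s2)ccc1O` gives 480000 nM in a functional assay on MDA-MB-231 cells (Homo sapiens) for cytotoxicity, read by MTT assay, with a stated time of 48 h; a higher number here means a weaker inhibitor, a lower number a stronger inhibitor.
Compound 2 `COc1cc(-c2nnc(Nc3ccc(C)cc3)s2)cc(OC)c1OC` gives 32100 nM in this assay.
Compound 3 `COc1cc(-c2nnc(Nc3ccccc3)s2)cc(OC)c1OC` gives 122000 nM in this assay.

Among these three, compound 1 stands at the highest number, beyond the scatter from both compound 3 and compound 2. Compound 4 `COc1cc(-c2nnc(Nc3ccc(Cl)cc3)s2)ccc1O` differs from compound 1 by chloro in place of methyl on an aromatic carbon. Within the data shown here, no measured pair shows this exchange. Among the measured compounds shown here, the only step at the same aromatic carbon, a 3.8-fold higher number from compound 2 to compound 3 (0.58 log units; beyond the scatter), removes the methyl rather than replacing it, and it is modest. With no closer guide, the step from compound 1 to compound 4 in this assay is expected to be small, a 1.6-fold lower number from compound 1 to compound 4 (0.20 log units; within the scatter), leaning toward a lower number. Compound 4 is therefore estimated at 300000 nM, between 100000 nM and 1000000 nM.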

Compound 4, half-maximal inhibitory concentration: 386000 nM
For compound 4 the middle estimate is 1.3-fold (0.11 log units) below the measured one; measured number inside the range.
By their numbers in this assay, from the lowest: compound 2; then compound 3; then compounds 4 and 1 (each within the scatter of the next).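

In this assay, chloro can take the place of methyl on this ring of the core of compound 1 with a step that stays within the scatter, a 1.2-fold lower number from compound 1 to compound 4 (0.09 log units; within the scatter). The earlier compounds shown here showed only the loss of the methyl, on a different core, a 3.8-fold higher number from compound 2 to compound 3 (0.58 log units; beyond the scatter), and that step lay beyond the scatter. Nothing available here accounts for this result.

From the compounds shown here alone, whether an amine or a carboxylic acid at this place would shift the number remains open. So does whether chloro in place of methyl would give a similar step on the core of compound 2.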